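Three Measured Ketones and an Expected Propyl Analogue

This account rests on a few compounds, and the source may have more. Where it says the series, first, only, none or still open, it means among the compounds named here.

Compound 1 `CC(=O)c1ccn(-c2ccc3c(c2)B(O)OC3)c1` in an ADME assay on L929 cells (Mus musculus) for cytotoxicity, read by resazurin assay, with a stated time of 72 h (a lower number here means a stronger inhibitor, a higher number a weaker inhibitor), gives > 10 ug/mL, a limit of the assay.
Compound 2 `O=C(c1cccc(Cl)c1)c1ccn(-c2ccc3c(c2)B(O)OC3)c1` gives > 10 ug/mL, a limit of the assay.
Compound 3 `COc1ccc(C(=O)c2ccn(-c3ccc4c(c3)B(O)OC4)c2)cc1` gives > 10 ug/mL, a limit of the assay.

Compound 3 therefore stands not at a number but at a limit, and the same holds for the two other values: the limit of > 10 ug/mL in this assay, at which 3 of the 3 values shown sit. The three measured steps, a step that the two limits leave unreadable from compound 1 to compound 2, a step that the two limits leave unreadable from compound 1 to compound 3 and a step that the two limits leave unreadable from compound 2 to compound 3, cannot be read in size or direction, since each of them runs from one limit to another.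

Compound 4 `CCCC(=O)c1ccn(-c2ccc3c(c2)B(O)OC3)c1` differs from compound 3 by propyl in place of 4-methoxyphenyl on a carbonyl carbon. The measured steps that bear on this change all exchange one group on the same carbonyl carbon, and none of them produced a value that fell below the limit. Because the limit of > 10 ug/mL in this assay, at which 3 of the 3 values shown sit, holds for every compound measured, no step beyond the scatter is expected in this assay for compound 4 either. Compound 4 is expected to give 30 ug/mL, with a range of 10 ug/mL to 100 ug/mL, most likely reported again as a limit. The estimated step is a step that the limit leaves unreadable from compound 3 to compound 4.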

Compound 4, half-maximal inhibitory concentration: > 10 ug/mL
Compound 4: a limit, no number; the forecaster's own chance of this, stated with the estimate: 85%; the middle value lies beyond the limit too.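

Among these compounds, compound 4 also gives a limit rather than a number, so no step from compound 1, compound 2 or compound 3 to compound 4 can be read: the limit of > 10 ug/mL in this assay, at which 4 of the 4 values shown sit. The compounds shown leave open whether the group on the carbonyl carbon changes cytotoxicity at all.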